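Propyl on the chain of compound 1

The compounds below may be only part of what the source reports. "The series", "measured", "known", "first", "only" and "open" are said of these compounds alone.

Going by the values given here, in a functional assay on HCT-116 cells (Homo sapiens) for antiproliferative activity, read by MTT assay, with a stated time of 48 h (on this read-out lower numbers stand for stronger inhibition and higher numbers for weaker inhibition), compound 1 (`CC(CCO)n1cnc2c(Cl)nc(F)nc21`) gives 19800 nM, the only true number so far. Compound 2 (`CC(CCO)n1cnc2c(Cl)ncnc21`) is reported only as a limit, > 50000 nM. Compound 3 (`CCCC(CCO)n1cnc2c(Cl)ncnc21`) is likewise reported only as a limit, > 50000 nM.

Compound 4 (`CCCCC(CCO)n1cnc2c(Cl)nc(F)nc21`) keeps the fluoro of compound 1 and differs from it in one place: propyl in place of hydrogen on a saturated chain carbon, two bonds along the chain from an aromatic nitrogen. Cut one bond further out, the same difference reads methyl to butyl.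

Among the compounds with values here, two measured steps bear on this change. Hydrogen in place of fluoro gives an at least 2.5-fold higher number from compound 1 to compound 2 (0.40 log units; beyond the scatter), and compound 4 retains that fluoro. Ethyl in place of hydrogen at the same chain carbon, in the series without fluoro, gives a step that the two limits leave unreadable from compound 2 to compound 3. Within the data shown here, this is the closest precedent for the chain change, but it shows neither size nor direction. No chain change has yet been read on a compound with a measured number, so no step beyond the scatter is expected in this assay, though a reading at the limit remains possible. The expected step is a 1.2-fold lower number from compound 1 to compound 4 (0.07 log units; within the scatter). For compound 4 the estimated value is 17000 nM, with an expected range of 6000 nM to 50000 nM.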

Compound 4, half-maximal inhibitory concentration: 13500 nM
Compound 4: the middle estimate sits 1.3-fold (0.10 log units) above what was measured; measured number inside the range.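

In this assay, propyl in place of hydrogen on a saturated chain carbon, two bonds along the chain from an aromatic nitrogen, gives a 1.5-fold lower number from compound 1 to compound 4 (0.17 log units; within the scatter). Going by these compounds alone, this is the first reading of a chain change between two true numbers, and it shows that with the fluoro kept, methyl to butyl at this carbon leaves compound 4 not separable from compound 1 in this series. The earlier chain step at the same carbon, in the series without fluoro, cannot be read because compound 2 and compound 3 are both reported only as limits of the assay, so it offers no size to set against the new step: the limit of > 50000 nM in this assay, at which 2 of the 4 values shown sit.

Within the data shown here, with only one readable chain step, no trend with chain length can be stated, and whether the fluoro is needed for a readable value with a longer chain on this carbon remains unsettled. Also open, from the compounds shown here alone, is how a longer chain such as hexyl, a ring such as cyclopropyl, or a chain ending in an amine or a carboxylic acid would read at this carbon on the core of compound 1.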